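The source may report more compounds than this note shows. Statements on the series, on what has been measured and on what is new or still open speak of the compounds shown alone.

In an ADME assay on microsomes from liver (Homo sapiens) for metabolic stability, read by LC-MS, with a stated time of 30 min, tested at 0.1 uM (a higher number here means that more of the compound is left, a lower number that less of the compound is left), compound 1 `COc1ccnc(Nc2cc3[nH]c(-c4cccc(C(F)(F)F)c4)nc3cn2)c1` gives 80%, compound 2 `COc1ccc(Nc2cc3[nH]c(-c4cccc(C(F)(F)F)c4)nc3cn2)nc1` gives 26%, and compound 3 `FC(F)(F)c1cccc(-c2nc3cnc(Nc4cnccn4)cc3[nH]2)c1` gives 43%. Compound 3 thus stands second of the three measured numbers, separated from the others by a number 37 percentage points lower from compound 1 to compound 3 (beyond the scatter) and by a number 17 percentage points higher from compound 2 to compound 3 (beyond the scatter). Compound 4 `FC(F)(F)c1cccc(-c2nc3cnc(Nc4cccnn4)cc3[nH]2)c1` differs from compound 3 by pyridazin-3-yl in place of pyrazin-2-yl on a nitrogen on an aromatic ring. Going by the values given here, every measured step so far changed the group on that same nitrogen: a number 54 percentage points lower from compound 1 to compound 2 (beyond the scatter) was large, and the two steps to compound 3 were large and modest. Such swaps have therefore moved this assay by clearly visible amounts in both directions, with nothing to favour one direction for compound 4. Compound 4 is expected to show a number 1 percentage points lower from compound 3 to compound 4 (within the scatter), no clear shift beyond the scatter. Compound 4 is estimated at 42%, between 20% and 65%.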

Compound 4, percent of the compound remaining: 84%
Compound 4: the middle estimate sits 42 percentage points below what was measured, outside the stated range (above it).
By their numbers in this assay, from the lowest: compound 2; then compound 3; then compounds 1 and 4 (each within the scatter of the next).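

In this assay the step of a number 41 percentage points higher from compound 3 to compound 4 (beyond the scatter) involves no change in atoms, only in how they are joined, so at this nitrogen the arrangement within the ring alone can produce a large move. The pyridazin-3-yl group also stands clear of the 5-methoxypyridin-2-yl group (a number 58 percentage points higher from compound 2 to compound 4 (beyond the scatter)), and the step of a number 4 percentage points higher from compound 1 to compound 4 (within the scatter) shows that a ring without methoxy can match the 4-methoxypyridin-2-yl group here. Going by these compounds, whether an amine or a methyl group on the pyridazin-3-yl ring would keep this number stays open. Nothing at hand gives a reason for the step.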